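This account rests on a few compounds, and the source may have more. Where it says the series, first, only, none or still open, it means among the compounds named here.

Measured in a physicochemical assay, read by spectrophotometry, with a stated time of 30 min; a lower number here means a stronger inhibitor, a higher number a weaker inhibitor:
- Compound 1 `O=C(CCCc1nc2ccccc2c(=O)[nH]1)N/N=C/c1cc(O)c(O)c(O)c1` gives 78000000 nM
- Compound 2 `COc1cc(/C=N/NC(=O)CCCc2nc3ccccc3c(=O)[nH]2)ccc1O` gives 236000000 nM
- Compound 3 `O=C(CCCc1nc2ccccc2c(=O)[nH]1)N/N=C/c1ccc(Cl)cc1` gives 353000000 nM

Compound 3 stands level with compound 2, the two lying within the scatter of each other, and both are weaker than compound 1 by a margin beyond the scatter. The next compound, compound 4 `COc1ccc(/C=N/NC(=O)CCCc2nc3ccccc3c(=O)[nH]2)cc1`, keeps the shared core and changes one group of compound 3, with methoxy in place of chloro on an aromatic carbon.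

Within the data shown here, three measured steps bear on this change. The closest is a 1.5-fold higher number from compound 2 to compound 3 (0.17 log units; within the scatter), where 4-chlorophenyl replaces 4-hydroxy-3-methoxyphenyl, the latter also carrying a methoxy. The two larger steps, a 3.0-fold higher number from compound 1 to compound 2 (0.48 log units; beyond the scatter) and a 4.5-fold higher number from compound 1 to compound 3 (0.66 log units; beyond the scatter), both start from the 3,4,5-trihydroxyphenyl group, which compound 4 does not carry. Among the measured compounds shown here, no measured compound has the 4-methoxyphenyl group itself, so the evidence is indirect. In this assay no step beyond the scatter is therefore expected, with at most a slight drift towards compound 2. The expected step is a 1.3-fold lower number from compound 3 to compound 4 (0.10 log units; within the scatter). For compound 4 the estimated value is 280000000 nM, with an expected range from 120000000 nM to 550000000 nM.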

Compound 4, half-maximal inhibitory concentration: 247000000 nM
Estimate against measurement, compound 4: 1.1-fold (0.05 log units) above, and the stated range covers the measured number.
By their numbers in this assay, from the lowest: compound 1; then compounds 2, 4 and 3 (each within the scatter of the next).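

In this assay, methoxy in place of chloro on an aromatic carbon, para to a large group, gives a 1.4-fold lower number from compound 3 to compound 4 (0.16 log units; within the scatter), so the assay does not separate these two groups at this place, although methoxy brings one hydrogen-bond acceptor and chloro none. The 4-methoxyphenyl group can now be compared directly with 4-hydroxy-3-methoxyphenyl, and a 1.0-fold higher number from compound 2 to compound 4 (0.02 log units; within the scatter) shows that these two cannot be told apart either, which leaves compound 2, compound 3 and compound 4 within the scatter of one another. Only the 3,4,5-trihydroxyphenyl group of compound 1 stands apart from the other three aryl groups, with a 3.2-fold higher number from compound 1 to compound 4 (0.50 log units; beyond the scatter) adding a third step beyond the scatter from that compound. Nothing in the data shown accounts for why these groups compare as they do.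

On these data alone, whether an amine or a carboxylic acid on the same aromatic carbon would shift the number beyond the scatter remains open. As far as these compounds go, it is also open whether a single hydroxy would match the three on compound 1, and what a longer chain to the shared core would do.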